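The source may report more compounds than this note shows. Statements on the series, on what has been measured and on what is new or still open speak of the compounds shown alone.

Compound 1 `CC(C)C(c1ccc(Cl)cc1)S(=O)(=O)Nc1nccs1`: in a functional assay on CHO cells for agonist activity at Free fatty acid receptor 2 (Homo sapiens), read by cAMP accumulation (a lower number here means a smaller maximal response, a higher number a larger maximal response), compound 1 gives < 30%, which is a limit of the assay, not a number.
Compound 2 `CC(C)C(C(N)=O)c1ccc(Cl)cc1`: in this assay compound 2 gives < 30%, again only a limit.
Compound 3 `CC(C)[C@H](C(=O)NCc1ccccc1)c1ccc(Cl)cc1`: in this assay compound 3 gives < 30%, also a limit.

Compound 3 therefore stands at the limit of < 30% in this assay, at which 3 of the 3 values shown sit, so no measured number places it among the others. Compound 4 `CC(C)[C@H](C(=O)Nc1cnns1)c1ccc(Cl)cc1` differs from compound 3 in one place: 1,2,3-thiadiazol-5-yl in place of benzyl on an amide-type nitrogen. No step between measured compounds is shown, so nothing among them indicates how large a change to expect in this assay. The expectation is a modest rise, possibly remaining at the limit. Compound 4 is estimated at 40%, between 15% and 75%. The expected step is a number at least 10 percentage points higher from compound 3 to compound 4 (that floor lies within the scatter).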

Compound 4, largest response reached (reported as efficacy), in percent of the reference or control that the assay uses: 48%
Compound 4: the middle estimate sits 8 percentage points below what was measured; the range from low to high includes it.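

Replacing benzyl with 1,2,3-thiadiazol-5-yl on the amide-type nitrogen gives a number at least 18 percentage points higher from compound 3 to compound 4 (beyond the scatter) in this assay. Compound 4 is thus the first compound shown with a measured response rather than a limit, so this position can lift the maximal response clear of the limit. The true step size stays unknown, and only its lower bound can be read, because the starting point is a limit: the limit of < 30% in this assay, at which 3 of the 4 values shown sit.

The compounds shown leave open whether a different ring on this nitrogen, such as a pyridine or an oxadiazole, would do the same. They also leave open whether a carboxylic acid there would raise the response further.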